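Swapping a bromophenyl for naphthyl on the benzylic arm

This account rests on a few compounds, and the source may have more. Where it says the series, first, only, none or still open, it means among the compounds named here.

Compound 2 `O=S(=O)(NCCCNCc1ccc(Br)cc1)c1cc(C(F)(F)F)cc(C(F)(F)F)c1` holds the lower of the two numbers measured in a functional assay on HPAC cells (Homo sapiens) for inhibition, read by MTT assay, with a stated time of 72 h (on this read-out lower numbers stand for stronger inhibition of growth and higher numbers for weaker inhibition of growth), giving 2900 nM, while compound 1 `O=S(=O)(NCCCNCc1ccccc1)c1cc(C(F)(F)F)cc(C(F)(F)F)c1` gives 3200 nM; the two sit within the scatter of each other. Compound 3 `O=S(=O)(NCCCNCc1cccc2ccccc12)c1cc(C(F)(F)F)cc(C(F)(F)F)c1` carries naphthalen-1-yl in place of 4-bromophenyl on a saturated chain carbon bound to an amine nitrogen. For the measured compounds named here, the only step measured at this position, a 1.1-fold lower number from compound 1 to compound 2 (0.04 log units; within the scatter), shows that altering the aromatic ring here barely moved the read-out. Compound 3 is therefore expected to change by a 1.1-fold lower number from compound 2 to compound 3 (0.05 log units; within the scatter) in this assay, with no shift beyond the scatter, and compound 3 is estimated at 2600 nM, between 1000 nM and 6500 nM.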

Compound 3, concentration for 50% growth inhibition: 2400 nM
Beside the measured number, compound 3's estimate is 1.1-fold (0.03 log units) above it, and the stated range covers the measured number.
By their numbers in this assay, from the lowest: compounds 3, 2 and 1 (each within the scatter of the next).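

In this assay, a second aromatic ring on the saturated chain carbon bound to an amine nitrogen gives a 1.2-fold lower number from compound 2 to compound 3 (0.08 log units; within the scatter) and, set against plain phenyl, a 1.3-fold lower number from compound 1 to compound 3 (0.12 log units; within the scatter) as well. Both steps lie within the scatter, so among these three compounds, naphthalen-1-yl, 4-bromophenyl and phenyl cannot be told apart at this position, even though the earlier pair tested only a single ring. No supporting data offer a reason for this sameness. Still open, on these data alone, is whether a carboxylic acid or an amine on the aromatic ring, or a longer chain at this place, would move the read-out beyond the scatter.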